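A few compounds are considered here, and "the series" means these few. Any claim that something is new, unique, unknown or untested is made for them only; others in the source may bear on it.

Compound 1 `O=C(NO)c1cccc(-c2cn([C@H]3C[C@@H](C(=O)O)N(Cc4ccccc4)C3)nn2)c1`: in an assay on Sf9 cells for inhibition of histone deacetylase 11 (Homo sapiens), read by fluorescence, tested at 0.5 uM (on this read-out lower numbers stand for less inhibition and higher numbers for more inhibition at the one concentration tested (going by the name of the read-out)), compound 1 gives 14%.
Compound 2 `O=C(NO)c1ccc(-c2cn([C@@H]3C[C@@H](C(=O)O)N(Cc4ccccc4)C3)nn2)cc1`: in this assay compound 2 gives < 10%, a limit of the assay rather than a number.
Compound 3 `O=C(NO)c1ccc(-c2cn([C@H]3C[C@H](C(=O)O)N(Cc4ccccc4)C3)nn2)cc1`: in this assay compound 3 gives < 10%, again only a limit.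

Compound 3 thus stands at the limit of < 10% in this assay, at which 2 of the 3 values shown sit. Going by the values given here, the one measured step leading to it, a step that the two limits leave unreadable from compound 2 to compound 3, is unreadable: both of its ends are limits, and the two ends are tied by the fact that compounds 2 and 3 differ only in the configuration as drawn. Compound 4 `O=C(NO)c1ccc(-c2cn([C@H]3C[C@@H](C(=O)O)N(Cc4ccccc4)C3)nn2)cc1` is reached by the two compounds have the same atoms and bonds and differ only in configuration as drawn: 1 of 2 stereo elements differ; a stereocentre at a saturated ring carbon is drawn R in compound 3 and S in compound 4. Among the compounds with values here, no measured step in this set resolves a configurational change, so nothing beyond the scatter can be predicted for it. The step that the limit leaves unreadable from compound 3 to compound 4 is expected to be no change beyond the scatter. The estimate for compound 4 is 8%, with a range from 0% to 18%.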

Compound 4, a percentage reported as inhibition, at one concentration (the size of the read-out at that concentration, not a potency): < 10%
Compound 4 was reported as a limit; the forecaster's own chance of this, stated with the estimate: 65%; the middle value is on the limit's open side.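

In this assay compound 4 gives < 10%, a limit of the assay, so this third configuration also yields no number. The steps among compound 2, compound 3 and compound 4 cannot be read, as each has limits at both ends. With 4-(hydroxycarbamoyl)phenyl in place of 3-(hydroxycarbamoyl)phenyl, the step is a number at least 4 percentage points lower from compound 1 to compound 4 (that floor lies within the scatter), so no change beyond the scatter is established.

Open, as far as these compounds go, is whether configuration affects this read-out at all, and whether a carboxamide in place of the carboxylic acid would give a value clear of the limit.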